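This account rests on a few compounds, and the source may have more. Where it says the series, first, only, none or still open, it means among the compounds named here.

Compound 3 `Nc1cc(OCc2cccc(Cl)c2)c2nn[nH]c2n1` gives 21 nM in an assay for inhibition of Myeloperoxidase (Homo sapiens), read by Amplex Red, with stated times of 10 min and 15 min (a higher number here means a weaker inhibitor, a lower number a stronger inhibitor), the lowest of the three numbers recorded so far. Compound 1 `Nc1cc(OCc2ccccc2Cl)c2nn[nH]c2n1` gives 26 nM in this assay, a gap that lies within the scatter, so no order between compound 3 and compound 1 can be claimed. Compound 2 `CS(=O)(=O)c1ccccc1COc1cc(N)nc2[nH]nnc12` gives 720 nM in this assay, well apart from both of the others. Compound 4 `Cn1ccc(-c2cccc(COc3cc(N)nc4[nH]nnc34)c2)n1` has not been measured; its change from compound 3 is 1-methyl-1H-pyrazol-3-yl in place of chloro on an aromatic carbon, so a single halogen gives way to a larger aromatic group. Among the compounds with values here, the one measured step that bears on this is a 28-fold higher number from compound 1 to compound 2 (1.44 log units; beyond the scatter), where a chloro was likewise exchanged for a larger group, and the loss was large. Within the data shown here, compound 4 carries a different entering group, so that step should not simply be copied, but its direction is the only guide the data give. Compound 4 is therefore expected to give a higher number than compound 3, by a 7.1-fold higher number from compound 3 to compound 4 (0.85 log units; beyond the scatter), a step likely beyond the scatter yet smaller than that from compound 1 to compound 2. The estimate for compound 4 is 150 nM, with a range from 40 nM to 800 nM.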

Compound 4, half-maximal inhibitory concentration: 21 nM
Estimate against measurement, compound 4: 7.1-fold (0.85 log units) above, and the stated range ends above it.
By their numbers in this assay, from the lowest: compounds 3, 4 and 1 (each within the scatter of the next); then compound 2.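

In this assay, the place on the six-membered aromatic ring of carbon only, meta to a large group, takes 1-methyl-1H-pyrazol-3-yl in place of chloro with no change at the digits printed from compound 3 to compound 4 (within the scatter), so a group of 6 heavy atoms with a five-membered aromatic ring and 2 hydrogen-bond acceptors stands where a single chlorine stood, at no measurable cost. A larger group on this ring therefore does not bring a loss by itself: the large step, a 28-fold higher number from compound 1 to compound 2 (1.44 log units; beyond the scatter), holds for methylsulfonyl in compound 2 and does not carry over to this change. Nothing measured here explains why the two exchanges of chloro end so differently.

The compounds shown leave open whether an amine, a carboxylic acid or a longer alkyl chain would be taken up at this place as 1-methyl-1H-pyrazol-3-yl is, and whether the methyl group on that ring matters at all. They also leave open whether methylsulfonyl at this same place would keep the value of compound 3 or lose as much as it does in compound 2.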